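Notes on a saturated-ring substituent change

The source may report more compounds than this note shows. Statements on the series, on what has been measured and on what is new or still open speak of the compounds shown alone.

Measured compounds:
compound 1 `Cc1nn(-c2ncnc3nc[nH]c23)c2c1C(C(=O)Nc1ccccc1)CC(=O)N2`: 10 nM
compound 2 `Cc1noc(C)c1COC1CC(=O)Nc2c1c(C)nn2-c1ncnc2nc[nH]c12`: 5 nM

In a functional assay on HEK293 cells for agonist activity at G-protein coupled receptor 39 (Homo sapiens), read by scintillation proximity assay and inositol phosphate accumulation, with a stated time of 75 min, in the presence of a further agent that is not named here (a higher number here means that more compound is needed for the effect, a lower number that less compound is needed), compound 2 stands at 5 nM. The nearest value is compound 1 at 10 nM, and the step of a 2.0-fold lower number from compound 1 to compound 2 (0.30 log units; within the scatter) lies within the scatter, so the two compounds are not separated. Compound 3 `Cc1nn(-c2ncnc3nc[nH]c23)c2c1C(c1ccc(F)cc1Cl)CC(=O)N2` carries the change (2-chloro-4-fluorophenyl in place of (3,5-dimethyl-1,2-oxazol-4-yl)methoxy on a saturated ring carbon). Among the compounds with values here, the only measured step at this position is a 2.0-fold lower number from compound 1 to compound 2 (0.30 log units; within the scatter), within the scatter, and no measured compound carries 2-chloro-4-fluorophenyl there, so the data give no direction. The step expected is a 1.6-fold higher number from compound 2 to compound 3 (0.20 log units; within the scatter), nothing beyond the scatter. Compound 3 is therefore estimated at 8 nM, with a range from 2 nM to 40 nM.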

Compound 3, half-maximal effective concentration: 9 nM
Beside the measured number, compound 3's estimate is 1.1-fold (0.05 log units) below it; the range from low to high includes it.
By their numbers in this assay, from the lowest: compounds 2, 3 and 1 (each within the scatter of the next).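

In this assay the position now tolerates a directly attached aromatic ring of carbon only: 2-chloro-4-fluorophenyl gives a 1.8-fold higher number from compound 2 to compound 3 (0.26 log units; within the scatter) and also a 1.1-fold lower number from compound 1 to compound 3 (0.05 log units; within the scatter) so compounds 1, 2 and 3 are not separated. A group with no hydrogen-bond acceptors thus takes the place of one that has them, with no step beyond the scatter.

Going by these compounds, whether an amine or a carboxylic acid on this saturated ring carbon would stay within the same range remains open. No evidence here explains why the three groups read alike.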